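The source may report more compounds than this note shows. Statements on the series, on what has been measured and on what is new or still open speak of the compounds shown alone.

Compound 1 `Cc1c(OCCCCOc2ccccc2C(=O)O)ccc(C(=O)CC2CCCC2)c1C`: 67.1%
Compound 2 `Cc1c(OCCCCOc2ccc(C(=O)O)cc2Cl)ccc(C(=O)CC2CCCC2)c1O`: 82.2%
Compound 3 `Cc1c(OCCCCOc2ccc(C(=O)O)cc2)ccc(C(=O)CC(C)C)c1O`: 88%

All three were read in an assay on HEK293 cells for positive allosteric modulation of metabotropic glutamate receptor 2 (Rattus norvegicus), read by thallium flux, with a stated time of 2.5 min; a lower number here means a smaller maximal response, a higher number a larger maximal response. Compound 2 stands second highest of the three numbers; compound 3 sits within the usual scatter of it, whereas compound 1 lies beyond the scatter and lower. For the measured compounds named here, no pair of the measured compounds differs in a single place, so no measured step is available for guidance.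

Compound 4 `Cc1c(OCCCCOCOc2ccc(C(=O)O)cc2)ccc(C(=O)CC2CCCC2)c1O` is not yet measured. It differs from compound 2 in one place: (4-carboxyphenoxy)methyl in place of 4-carboxy-2-chlorophenyl on an oxygen on a saturated carbon.

Going by the values given here, with no matching measured step, the expectation is for a step no larger than the scatter, in no clear direction, and the expected step is a number 2.2 percentage points lower from compound 2 to compound 4 (within the scatter). In this assay compound 4 is accordingly estimated at 80%, within a range of 60% to 95%.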

Compound 4, largest response reached (reported as percent of maximum), in percent of the reference or control that the assay uses: 95.4%
Beside the measured number, compound 4's estimate is 15.4 percentage points below it; measured number outside the range, above it.
By their numbers in this assay, from the lowest: compound 1; then compounds 2, 3 and 4 (each within the scatter of the next, the first and the last beyond it).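

For the compounds shown here, exchanging 4-carboxy-2-chlorophenyl for (4-carboxyphenoxy)methyl on an oxygen on a saturated carbon gives a number 13.2 percentage points higher from compound 2 to compound 4 (beyond the scatter) in this assay and is the first single-place step measured. This position therefore accepts the longer (4-carboxyphenoxy)methyl group, and the maximal response rises with it. No measured evidence bears on the origin of this step.

The change removes the chlorine and adds the oxygen and methylene link together, so the contribution of each stays unresolved. Going by these compounds, whether an amide in place of the carboxylic acid would retain the response also remains open.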